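Dichlorophenyl in place of methylphenyl on the oxime carbon

The compounds below may be only part of what the source reports. "The series", "measured", "known", "first", "only" and "open" are said of these compounds alone.

Measured compounds:
compound 1 `CO/N=C(\CCN1CCN(c2ccccn2)CC1)c1ccccc1C` — 80%
compound 2 `CO/N=C(/CCN1CCN(c2ccccn2)CC1)c1ccccc1C` — 72%

In a functional assay on HEK293 cells with D(4) dopamine receptor (Homo sapiens) as the target, read by FLIPR (a lower number here means a smaller maximal response, a higher number a larger maximal response), compound 2 gives the lower of the two numbers, with compound 1 80% the nearest, and the step of a number 8 percentage points lower from compound 1 to compound 2 (within the scatter) stays within the scatter, which fits (the fact that compounds 1 and 2 differ only in the configuration as drawn). Compound 3 `CO/N=C(/CCN1CCN(c2ccccn2)CC1)c1ccc(Cl)c(Cl)c1` is not yet measured in this assay. It differs from compound 2 by 3,4-dichlorophenyl in place of 2-methylphenyl on a carbon with a double bond to nitrogen. Among the measured compounds shown here, the only measured step concerns configuration, so none bears on this aryl change. Compound 3 is therefore expected near compound 2, with a wide range, at 65% between 35% and 90%. That expectation means a step of a number 7 percentage points lower from compound 2 to compound 3 (within the scatter).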

Compound 3, largest response reached (reported as efficacy), in percent of the reference or control that the assay uses: 63%
Estimate against measurement, compound 3: 2 percentage points above; measured number inside the range.
By their numbers in this assay, from the lowest: compounds 3, 2 and 1 (each within the scatter of the next, the first and the last beyond it).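

In this assay, the step for the aryl group on the carbon with a double bond to nitrogen is a number 9 percentage points lower from compound 2 to compound 3 (within the scatter), so this position takes 3,4-dichlorophenyl in place of 2-methylphenyl without the two numbers separating beyond the scatter. With the added chlorine atoms, compound 3 still gives 63%. Nothing at hand explains this step.

As far as these compounds go, it remains open whether the same aryl change would read alike in the other double-bond configuration. Also open, from the compounds shown here alone, is how an aminophenyl group, a carboxyphenyl group or a longer chain would behave on this carbon.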